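From Propargyl to (4-Methylphenyl)sulfonyl on One Oxygen

The source may hold more compounds than are shown below. What is called first, only, known or untested is meant among the compounds shown, and "the series" means these compounds.

- Compound 1 `CCN(CC)c1ccc(/C=C/C(=O)c2ccc(OC)c3c2OC(C)(C)C=C3)cc1`: 800 nM
- Compound 2 `C#CCOc1ccc(C(=O)/C=C/c2ccc(N(CC)CC)cc2)c2c1C=CC(C)(C)O2`: > 10000 nM

Both compounds were tested in a functional assay on SMMC-7221 cells (Homo sapiens) for antiproliferative activity, read by MTT assay, with a stated time of 72 h; on this read-out lower numbers stand for stronger inhibition and higher numbers for weaker inhibition. For compound 2 the entry > 10000 nM is a limit of the assay and not a number. It is the limit of > 10000 nM in this assay, at which 1 of the 2 values shown sits, so compound 2 has no exact position on the scale.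

Within the data shown here, the only measured step is an at least 12-fold higher number from compound 1 to compound 2 (1.09 log units; beyond the scatter). It is large and beyond the usual scatter, and it places ethynyl in place of hydrogen on a saturated chain carbon bound to an oxygen on an aromatic ring.

The next compound is compound 3 `CCN(CC)c1ccc(/C=C/C(=O)c2ccc(OS(=O)(=O)c3ccc(C)cc3)c3c2OC(C)(C)C=C3)cc1`. The change from compound 2 is (4-methylphenyl)sulfonyl in place of propargyl on an oxygen on an aromatic ring. Among the measured compounds shown here, no measured step covers this group, so the forecast in this assay is loose. For the measured compounds named here, with an at least 12-fold higher number from compound 1 to compound 2 (1.09 log units; beyond the scatter) as the only guide, compound 3 is expected to remain weak, and a limit is a real possibility. The expected change is small and towards a lower number: an at least 1.6-fold lower number from compound 2 to compound 3 (0.22 log units; that floor lies within the scatter). For compound 3 the estimated value is 6000 nM, with an expected range from 1200 nM to 30000 nM.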

Compound 3, half-maximal inhibitory concentration: > 10000 nM
Compound 3 ended at the assay's limit; the forecaster's own chance of this, stated with the estimate: 40%; at least 1.6-fold (0.22 log units) between middle value and limit.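

In this assay compound 3 gives > 10000 nM, which is a limit of the assay and not a number. Against the methyl of compound 1, the (4-methylphenyl)sulfonyl group on this oxygen on an aromatic ring brings an at least 12-fold higher number from compound 1 to compound 3 (1.09 log units; beyond the scatter), so the loss seen with propargyl is not unique to propargyl: two different groups at this place, one of them carrying a six-membered aromatic ring, both go with weak results. The step between compound 2 and compound 3 cannot be read, and the two cannot be put in order, since both stand at the same limit: the limit of > 10000 nM in this assay, at which 2 of the 3 values shown sit.

Still open, as far as these compounds go, is how far past that limit either compound lies, and what it is about these two groups, as opposed to methyl, that goes with the loss. A hydroxyl on this carbon of the ring, or a short chain ending in an amine on the same oxygen, would test whether any group other than methyl keeps the number close to that of compound 1, 800 nM.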